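The compounds below may be only part of what the source reports. "The series", "measured", "known", "first", "only" and "open" are said of these compounds alone.

Working notes on the series. Of the compounds shown here, three share a core and have been measured in an assay on isolated protein for inhibition of tyrosine-protein kinase receptor UFO (Homo sapiens), read by ELISA; a higher number here means a weaker inhibitor, a lower number a stronger inhibitor. Compound 1 `Nc1ncnc2[nH]cc(-c3ccc(NC(=O)c4cn(CC5CCOCC5)cc(-c5ccc(F)cc5)c4=O)cc3)c12` gives 0.2 nM. Compound 3 `Cn1cc(-c2ccc(NC(=O)c3cn(CC4CCOCC4)cc(-c4ccc(F)cc4)c3=O)c(F)c2)c2c(N)ncnc21` gives 0.2 nM. Compound 2 `Cn1cc(-c2ccc(NC(=O)c3cn(CC4CCCCC4)cc(-c4ccc(F)cc4)c3=O)cc2)c2c(N)ncnc21` gives 2.3 nM, which is the highest of the three numbers; the gap from compound 2 to compound 1 and the gap from compound 2 to compound 3 each lie beyond the scatter, so compound 2 is the weakest of the measured set. No pair among these three differs in one place only, so no single-change step can be read from them.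

Compound 4 `Cn1cc(-c2ccc(NC(=O)c3cn(CC4CCCO4)cc(-c4ccc(F)cc4)c3=O)cc2)c2c(N)ncnc21` has not been measured. It differs from compound 2 by oxolan-2-yl in place of cyclohexyl on a saturated chain carbon bound to an aromatic nitrogen. The two measured compounds that carry an oxygen-containing saturated ring at this position, compound 1 and compound 3, both show lower numbers than compound 2, though each of them also differs from compound 2 elsewhere, so this is a loose pointer rather than a step.

On that basis a step downward in this assay of moderate size is expected from compound 2 to compound 4, a 2.9-fold lower number from compound 2 to compound 4 (0.46 log units; beyond the scatter). Compound 4 is estimated at 0.8 nM, with a range from 0.25 nM to 2.5 nM.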

Compound 4, half-maximal inhibitory concentration: 1.2 nM
Compound 4: middle estimate off by 1.5-fold (0.18 log units), on the low side; the range from low to high includes it.
By their numbers in this assay, from the lowest: compounds 1 and 3 (each within the scatter of the next); then compounds 4 and 2 (each within the scatter of the next).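

Going by these compounds alone, the first single-change step, read in this assay, is a 1.9-fold lower number from compound 2 to compound 4 (0.28 log units; within the scatter), so the exchange of cyclohexyl for oxolan-2-yl on a saturated chain carbon bound to an aromatic nitrogen does not separate these two compounds. This position therefore carries either a six-membered ring of carbon only or a five-membered ring with one hetero atom, and the change from no hydrogen-bond acceptor to one in this group gives no step beyond the scatter. Nothing on hand gives an explanation for this outcome.

Ring size and the ring oxygen change together in this step, so neither can be read alone, and the steps that would link compound 1 or compound 3 to compound 2 or compound 4 cannot be read, as each of those pairs differs in more than one place. Also open, as far as these compounds go, is how this assay responds at the same position to a ring bearing an amine, such as piperidin-4-yl, or to a chain ending in a carboxylic acid.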